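Fluoro in place of hydrogen on compound 3

A few compounds are considered here, and "the series" means these few. Any claim that something is new, unique, unknown or untested is made for them only; others in the source may bear on it.

In a functional assay on HL-60 cells (Homo sapiens) for cytotoxicity, read by WST assay, with a stated time of 48 h (on this read-out lower numbers stand for an effect already at smaller amounts and higher numbers for an effect only at larger amounts of compound), compound 1 (`Oc1ccccc1C[C@H]1COC[C@@H]1Cc1ccc(Cl)c(Cl)c1`) gives 34000 nM while compound 2 (`Oc1cccc(C[C@H]2COC[C@@H]2Cc2ccc(Cl)c(Cl)c2)c1`) gives 31000 nM and compound 3 (`Fc1cccc(C[C@H]2COC[C@@H]2Cc2ccc(Cl)c(Cl)c2)c1`) gives 20000 nM on the same scale. Compound 3 cannot be separated from the other two, since a 1.6-fold lower number from compound 2 to compound 3 (0.19 log units; within the scatter) and a 1.7-fold lower number from compound 1 to compound 3 (0.23 log units; within the scatter) are the steps that reach it.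

Compound 4 (`Fc1ccc(C[C@H]2COC[C@@H]2Cc2ccc(Cl)c(Cl)c2)cc1F`) keeps the core of compound 3 and differs by fluoro in place of hydrogen on an aromatic carbon in one place. This is fluoro in place of hydrogen on an aromatic carbon, ortho to a fluoro group and para to a large group.

Among the measured compounds shown here, no measured step makes exactly this change, so the evidence is indirect. The closest case is fluoro in place of hydroxy on an aromatic carbon, seen as a 1.6-fold lower number from compound 2 to compound 3 (0.19 log units; within the scatter) here, and moving the hydroxy group gave a 1.1-fold lower number from compound 1 to compound 2 (0.04 log units; within the scatter) in the same series. None of the three compounds stands apart from the others. With compound 3 at 20000 nM as the starting point, no step beyond the scatter is expected in this assay for this change. The estimated change is a 1.2-fold lower number from compound 3 to compound 4 (0.07 log units; within the scatter) and no more. Compound 4 is expected at 17000 nM with 8500 nM as the lower end and 34000 nM as the upper end of the estimate.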

Compound 4, half-maximal effective concentration: 18000 nM
The estimate for compound 4 lay 1.1-fold (0.02 log units) below the measured number, within the range that was stated.
By their numbers in this assay, from the lowest: compounds 4, 3, 2 and 1 (each within the scatter of the next).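

In this assay, fluoro in place of hydrogen on the aromatic carbon ortho to a fluoro group and para to a large group gives a 1.1-fold lower number from compound 3 to compound 4 (0.05 log units; within the scatter), so compound 4 cannot be separated from compound 3. Among the compounds shown here, this is the first direct reading of this change, as the earlier steps only exchanged hydroxy for fluoro or moved the hydroxy group, and it shows that this position of the aromatic ring accepts an added fluoro without a step that stands out from the scatter. No measurement among the data shown bears on this result, so nothing can be said about what lies behind it.

The compounds shown leave open whether any group at this place can shift the number beyond the scatter, since every step read so far in this series stays within it. A methoxy group, an amine or a carboxylic acid on this aromatic carbon would test that question more sharply than fluoro, and the compounds here give no indication of how any of them would read.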